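Dropping the 3-methylbut-2-en-1-yl group from compound 2

This account rests on a few compounds, and the source may have more. Where it says the series, first, only, none or still open, it means among the compounds named here.

In a functional assay on HeLa cells (Homo sapiens) for inhibition, read by MTT assay, with a stated time of 72 h (a higher number here means a weaker inhibitor, a lower number a stronger inhibitor), compound 1 `COc1ccc(/C=C/C(=O)c2c(OC)cc(O)c(CC=C(C)C)c2O)cc1OC` gives 27700 nM. Compound 2 `COc1cc(/C=C/C(=O)c2c(OC)cc(O)c(CC=C(C)C)c2O)cc(OC)c1OC` gives > 50000 nM, which is a limit and not a number. Going by the values given here, the one measured step, an at least 1.8-fold higher number from compound 1 to compound 2 (0.25 log units; that floor lies within the scatter), is methoxy in place of hydrogen on an aromatic carbon, a different change from the next one. Compound 3 `COc1cc(/C=C/C(=O)c2c(O)cc(O)cc2OC)cc(OC)c1OC` carries hydrogen in place of 3-methylbut-2-en-1-yl on an aromatic carbon, hydrogen in place of 3-methylbut-2-en-1-yl on an aromatic carbon. Among the compounds with values here, no measured step covers this change, so none beyond the scatter is expected. The expected step, a number no higher from compound 2 to compound 3 (the limit leaves the size open), is only an estimate. For compound 3 the estimated value is 50000 nM, with an expected range of 25000 nM to 100000 nM.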

Compound 3, half-maximal inhibitory concentration: 18900 nM
Compound 3: middle estimate off by 2.6-fold (0.42 log units), on the high side; measured number outside the range, below it.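

In this assay, the series now has a step beyond the scatter, an at least 2.6-fold lower number from compound 2 to compound 3 (0.42 log units; beyond the scatter), for hydrogen in place of 3-methylbut-2-en-1-yl on an aromatic carbon. In this pair the chain is dispensable, and losing it makes the inhibitor stronger, not weaker. The true size of the step stays open, as the entry for compound 2 is a limit and not a number: the limit of > 50000 nM in this assay, at which 1 of the 3 values shown sits.

Going by these compounds, whether a methyl group or an amine at this position would keep the lower number remains open. On these data alone, whether the same change would lower the number for compound 1 also remains open.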